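A few compounds are considered here, and "the series" means these few. Any claim that something is new, unique, unknown or untested is made for them only; others in the source may bear on it.

Compound 1 `Cc1nc(NCc2ccc(C(F)(F)F)cc2)nc(Nc2c(C)cccc2C)n1` and compound 3 `Cc1cc(C)c(Nc2nc(C)nc(NCc3ccc(C(F)(F)F)cc3)n2)c(C)c1` share one core and differ in a single place: methyl in place of hydrogen on an aromatic carbon. In an assay on isolated protein for binding affinity to corticotropin-releasing factor receptor 1 (Homo sapiens) (on this read-out higher numbers stand for weaker inhibition and lower numbers for stronger inhibition), compound 1 gives only a limit of the assay, > 10000 nM. In this assay compound 3 gives 1690 nM. The step of an at least 5.9-fold lower number from compound 1 to compound 3 (0.77 log units; beyond the scatter) is therefore at least modest. Compound 2 `CCN(Cc1ccccc1)c1nc(C)nc(Nc2c(C)cccc2C)n1` is built on a different core; the difference between the two cores is not broken down here. In this assay compound 2 also gives only a limit of the assay, > 10000 nM. Compound 4 `CCN(Cc1ccccc1)c1nc(C)nc(Nc2c(C)cc(C)cc2C)n1` has not yet been measured and differs from compound 2 by the same change, (methyl in place of hydrogen on an aromatic carbon). As far as these compounds go, because compound 2 sits at the limit of > 10000 nM in this assay, at which 2 of the 3 values shown sit, its true starting point is unknown. Among the compounds with values here, the only measured guide for this change is the step of an at least 5.9-fold lower number from compound 1 to compound 3 (0.77 log units; beyond the scatter). For the same change the step is expected to be an at least 3.3-fold lower number from compound 2 to compound 4 (0.52 log units; beyond the scatter). Compound 4 is accordingly expected to give 3000 nM in this assay, somewhere between 800 nM and 15000 nM.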

Compound 4, inhibition constant: 1470 nM
For compound 4 the middle estimate is 2.0-fold (0.31 log units) above the measured one, within the range that was stated.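

On the core of compound 2, the methyl that turns 2,6-dimethylphenyl into 2,4,6-trimethylphenyl gives an at least 6.8-fold lower number from compound 2 to compound 4 (0.83 log units; beyond the scatter) in this assay. Set beside the earlier step, this shows the change lowering the number in the same direction on both cores, which makes it the one pattern these four compounds support: the same change on two cores in this assay, an at least 5.9-fold lower number (0.77 log units; beyond the scatter) from compound 1 to compound 3 and an at least 6.8-fold lower number (0.83 log units; beyond the scatter) from compound 2 to compound 4; the limit leaves it open whether they differ It does not show how large the step truly is on either core, or that the change carries over by an equal amount, because each starting compound gives only a limit: the limit of > 10000 nM in this assay, at which 2 of the 4 values shown sit.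

As far as these compounds go, what a chlorine atom or a methoxy group would do at this same place on the ring remains open. From the compounds shown here alone, whether the step holds on any further core also remains open.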